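A few compounds are considered here, and "the series" means these few. Any claim that something is new, unique, unknown or untested is made for them only; others in the source may bear on it.

In a functional assay on MDBK cells (Bos taurus) for cytotoxicity (a lower number here means that less compound is tolerated, a higher number that more compound is tolerated), compound 1 `CO/N=C(\C#N)C(=O)NCC1=NOC(C(C)(C)C)C1` gives > 100 ug/mL, which is a limit and not a number. Compound 2 `CC(C)O/N=C(\C#N)C(=O)NCC1=NOC(C(C)(C)C)C1` gives > 100 ug/mL, which is also a limit. Among the measured compounds shown here, the only measured step, a step that the two limits leave unreadable from compound 1 to compound 2, therefore has no size that can be read, and the evidence amounts to the limit of > 100 ug/mL in this assay, at which 2 of the 2 values shown sit. Compound 3 `C=CCO/N=C(\C#N)C(=O)NCC1=NOC(C(C)(C)C)C1` differs from compound 2 by allyl in place of isopropyl on an oxygen, with allyl in place of isopropyl on an oxygen. No change beyond the scatter is expected in this assay, so the expected step is a step that the limit leaves unreadable from compound 2 to compound 3. For compound 3 the estimated value is 150 ug/mL, with an expected range of 70 ug/mL to 300 ug/mL.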

Compound 3, half-maximal cytotoxic concentration: > 100 ug/mL
Compound 3: only a limit was reported; the forecaster's own chance of this, stated with the estimate: 85%; the middle value lies beyond the limit too.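

Among the compounds shown here, compound 1, compound 2 and compound 3 all give only limits in this assay, so no step among them can be read: the limit of > 100 ug/mL in this assay, at which 3 of the 3 values shown sit. As far as these compounds go, whether methyl, isopropyl and allyl on that oxygen differ at all in this assay stays open.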